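This account rests on a few compounds, and the source may have more. Where it says the series, first, only, none or still open, it means among the compounds named here.

Of the compounds shown here, three of one shared core have been tested in an ADME assay on MT4 cells (Homo sapiens) for cytotoxicity, read by MTT assay; a lower number here means that less compound is tolerated, a higher number that more compound is tolerated. Compound 1 `COC(=O)c1ccc(NC(=O)CSc2nncnc2-c2ccccc2Cl)c(Br)c1` gives 59000 nM, compound 2 `O=C(CSc1nncnc1-c1ccccc1Cl)Nc1ccccn1` gives 172000 nM, and compound 3 `O=C(CSc1nncnc1-c1ccccc1Cl)Nc1ccccc1[N+](=O)[O-]` gives 63000 nM. Compound 2 therefore stands highest of the three, so it is the best tolerated. Going by the values given here, the one measured single change, a 2.7-fold lower number from compound 2 to compound 3 (0.44 log units; beyond the scatter), came from putting 2-nitrophenyl in place of pyridin-2-yl on an amide-type nitrogen. Compound 4 `O=C(CSc1nncnc1-c1ccccc1Cl)c1ccc(Br)cc1Br` differs from compound 2 as follows: 2,4-dibromophenyl in place of (pyridin-2-yl)amino on a carbonyl carbon. That change also removes the hetero ring and the amide-type nitrogen, and both compound 1 and compound 3 sit lower than compound 2, so a modest drop is expected, a 2.9-fold lower number from compound 2 to compound 4 (0.46 log units; beyond the scatter). Compound 4 is therefore estimated at 60000 nM, within 25000 nM to 150000 nM.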

Compound 4, half-maximal cytotoxic concentration: 28000 nM
For compound 4 the middle estimate is 2.1-fold (0.33 log units) above the measured one, within the range that was stated.
By their numbers in this assay, from the lowest: compound 4; then compounds 1 and 3 (each within the scatter of the next); then compound 2.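

In this assay, the earlier step changed only the ring on the amide-type nitrogen, whereas this one removes that nitrogen as well, giving a 6.1-fold lower number from compound 2 to compound 4 (0.79 log units; beyond the scatter). The change replaces the hetero ring with a carbon-only ring carrying two bromines and also removes the hydrogen-bond donor and acceptor, so this single step cannot show which part accounts for the drop. No measured evidence explains the result. A (2,4-dibromophenyl)amino group on the same carbonyl carbon would keep the nitrogen alongside the new ring. As far as these compounds go, how it would compare with compound 2 and compound 4 remains open.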